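A few compounds are considered here, and "the series" means these few. Any claim that something is new, unique, unknown or untested is made for them only; others in the source may bear on it.

Compound 1 `Cc1nc(S(C)(=O)=O)ccc1Oc1ncnc(OC2CCN(C(=O)OC(C)C)CC2)c1F`: 142 nM
Compound 2 `Cc1nc(S(C)(=O)=O)ccc1Oc1ncnc(OC2CCN(C(=O)O[C@@H](C)CF)CC2)c1F`: 1680 nM
Compound 3 `Cc1nc(S(C)(=O)=O)ccc1Oc1ncnc(OC2CCN(C(=O)O[C@@H](C)C(F)(F)F)CC2)c1F`: 109 nM

In a functional assay on isolated protein for inhibition of Glucose-dependent insulinotropic receptor (Rattus norvegicus), read by HTRF and cAMP accumulation (a lower number here means that less compound is needed, a higher number that more compound is needed for the effect), compound 1 gives 142 nM, the second highest of the three numbers; compound 3 sits within the scatter of it (a 1.3-fold lower number from compound 1 to compound 3 (0.11 log units; within the scatter)), while compound 2 lies furthest away (a 12-fold higher number from compound 1 to compound 2 (1.07 log units; beyond the scatter)). Compound 4 `Cc1nc(S(C)(=O)=O)ccc1Oc1ncnc(OC2CCN(C(=O)OC3(C(F)(F)F)COC3)CC2)c1F` has not yet been measured. It differs from compound 1 by 3-(trifluoromethyl)oxetan-3-yl in place of isopropyl on an oxygen next to a carbonyl group. For the measured compounds named here, two measured steps bear on this change: a 1.3-fold lower number from compound 1 to compound 3 (0.11 log units; within the scatter), where a trifluoromethyl group entered on the same oxygen and little changed, and a 15-fold lower number from compound 2 to compound 3 (1.19 log units; beyond the scatter), where trifluoromethyl in place of fluoromethyl gave a large gain. Going by these compounds, neither step brings in a ring, so the oxetane itself is untested here. Compound 4 is therefore expected to land near compound 1, possibly somewhat higher, a 2.1-fold higher number from compound 1 to compound 4 (0.32 log units; beyond the scatter). The estimate for compound 4 is 300 nM, with a range from 70 nM to 1500 nM.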

Compound 4, half-maximal effective concentration: 342 nM
Estimate against measurement, compound 4: 1.1-fold (0.06 log units) below; low and high end bracket the measured number.
By their numbers in this assay, from the lowest: compounds 3 and 1 (each within the scatter of the next); then compound 4; then compound 2.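

In this assay, 3-(trifluoromethyl)oxetan-3-yl is the first ring shown on this oxygen, and it needs more compound than isopropyl (a 2.4-fold higher number from compound 1 to compound 4 (0.38 log units; beyond the scatter)) and more than 1-(trifluoromethyl)ethyl (a 3.1-fold higher number from compound 3 to compound 4 (0.50 log units; beyond the scatter)). It still needs less than the singly fluorinated chain (a 4.9-fold lower number from compound 2 to compound 4 (0.69 log units; beyond the scatter)). The position therefore accepts this four-membered ring, though with no gain over the two best chains. Going by these compounds, whether plain oxetan-3-yl or cyclobutyl would behave alike remains open, so the separate parts played by the ring and the trifluoromethyl group cannot yet be told apart. No measurement shown here accounts for these differences.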